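The source may report more compounds than this note shows. Statements on the series, on what has been measured and on what is new or still open speak of the compounds shown alone.

In a functional assay on cells (Cancer cell lines, Homo sapiens) for inhibition (a higher number here means a weaker inhibitor of growth, a lower number a stronger inhibitor of growth), compound 2 `Cc1cn2c(/C=N/NC(=N)N)c(-c3ccsc3)nc2s1` gives 22400 nM, within the scatter of both its measured neighbours, compound 1 `Cc1cc(-c2nc3sc(C)cn3c2/C=N/NC(=N)N)c(C)s1` at 13500 nM and compound 3 `N=C(N)N/N=C/c1c(-c2ccsc2)nc2sccn12` at 31600 nM. Compound 4 `Cc1cn2c(/C=N/NC(=N)N)c(-c3cccs3)nc2s1` differs from compound 2 by one change: thiophen-2-yl in place of thiophen-3-yl on an aromatic carbon. Going by the values given here, two measured steps bear on it. The first, on the thiophene substituent, is a 1.7-fold higher number from compound 1 to compound 2 (0.22 log units; within the scatter). The second, at another place, is a 1.4-fold higher number from compound 2 to compound 3 (0.15 log units; within the scatter). Among the compounds with values here, both lie within the scatter, and no measured compound carries thiophen-2-yl, so no step beyond the scatter is expected in this assay. The estimated step is a 1.0-fold lower number from compound 2 to compound 4 (0.01 log units; within the scatter). For compound 4 the expected value is 22000 nM, with an estimated range of 10000 nM to 46000 nM.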

Compound 4, concentration for total growth inhibition: 18600 nM
Compound 4: the middle estimate sits 1.2-fold (0.07 log units) above what was measured; measured number inside the range.
By their numbers in this assay, from the lowest: compounds 1, 4, 2 and 3 (each within the scatter of the next, the first and the last beyond it).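

In this assay, thiophen-2-yl in place of thiophen-3-yl, the same atoms joined differently, gives a 1.2-fold lower number from compound 2 to compound 4 (0.08 log units; within the scatter), so the point of attachment of the thiophene on this aromatic carbon does not register beyond the scatter. Thiophen-2-yl in place of 2,5-dimethylthiophen-3-yl gives a 1.4-fold higher number from compound 1 to compound 4 (0.14 log units; within the scatter), also within the scatter. Nothing on hand offers an explanation for these small steps. Open, from the compounds shown here alone, is whether a group other than a thiophene at this carbon, such as phenyl, an amine or a carboxylic acid, would give a step beyond the scatter.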